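A few compounds are considered here, and "the series" means these few. Any claim that something is new, unique, unknown or untested is made for them only; others in the source may bear on it.

Of the compounds shown here, three sharing one core have been tested in an assay on isolated protein for binding affinity to adenosine receptor A1 (Bos taurus); a lower number here means a stronger inhibitor, a higher number a weaker inhibitor. Compound 1 `OC1CCC(Nc2nc(-c3ccccc3)nc3c2nnn3Cc2ccccc2F)CC1` gives 1850000 nM, compound 3 `CCCCNc1nc(-c2ccccc2)nc2c1nnn2Cc1ccccc1C(F)(F)F` gives 6500000 nM, and compound 2 `CCNc1nc(-c2ccccc2)nc2c1nnn2Cc1ccccc1Cl` gives 463000000 nM, the highest of the three numbers, far beyond the scatter from both of the others. Compound 4 `OCCNc1nc(-c2ccccc2)nc2c1nnn2Cc1ccccc1Cl` differs from compound 2 in one place: hydroxy in place of hydrogen on a saturated chain carbon, two bonds along the chain from a nitrogen on an aromatic ring. No pair among the measured compounds differs in a single place, so the effect of this change is not directly shown; the two compounds with lower numbers, compound 1 and compound 3, differ from compound 2 in several places at once. Still, a step downward beyond the scatter is expected from compound 2 to compound 4, a 9.3-fold lower number from compound 2 to compound 4 (0.97 log units; beyond the scatter). Compound 4 is thus estimated at 50000000 nM, in a range from 4000000 nM to 500000000 nM.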

Compound 4, inhibition constant: 116000000 nM
Compound 4: the middle estimate sits 2.3-fold (0.37 log units) below what was measured, within the range that was stated.
By their numbers in this assay, from the lowest: compound 1; then compound 3; then compound 4; then compound 2.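

Among these compounds, compound 4 gives the first direct reading of this change in this assay: going from ethylamino to (2-hydroxyethyl)amino gives a 4.0-fold lower number from compound 2 to compound 4 (0.60 log units; beyond the scatter), a modest step. For this one pair, hydroxy on the saturated chain carbon lowers the number rather than raising it. No available evidence bears on the reason for this step.

Going by these compounds, whether a methoxy group or an amine on the same carbon would give a step in the same direction remains open. So does whether hydroxy on a longer chain would do the same.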